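The source may report more compounds than this note shows. Statements on the series, on what has been measured and on what is new or still open speak of the compounds shown alone.

Measured compounds:
Compound 1 `Cc1cc(O)c(C2=NN(c3ccc(S(N)(=O)=O)cc3)C(c3ccccc3O)C2)cc1Cl` gives 3020 nM in a functional assay on HCT-116 cells (Homo sapiens) for antiproliferative activity, with a stated time of 48 h; a lower number here means a stronger inhibitor of growth, a higher number a weaker inhibitor of growth.
Compound 2 `Cc1cc(O)c(C2=NN(c3ccc(S(N)(=O)=O)cc3)C(c3ccccc3Cl)C2)cc1Cl` gives 3150 nM in this assay.
Compound 3 `Cc1cc(O)c(C2=NN(c3ccc(S(N)(=O)=O)cc3)C(/C=C/c3ccccc3)C2)cc1Cl` gives 14600 nM in this assay.

Among these three, compound 3 stands at the highest number, the weakest inhibitor of growth of the set. The two steps that lead to it are of similar size: a 4.8-fold higher number from compound 1 to compound 3 (0.68 log units; beyond the scatter) and a 4.6-fold higher number from compound 2 to compound 3 (0.67 log units; beyond the scatter), both beyond the scatter, while the step of a 1.0-fold higher number from compound 1 to compound 2 (0.02 log units; within the scatter) is within it. The aryl groups of compounds 1 and 2 thus give the same result, and the 2-phenylethenyl group of compound 3 stands apart.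

Compound 4 `COc1ccc(C2CC(c3cc(Cl)c(C)cc3O)=NN2c2ccc(S(N)(=O)=O)cc2)cc1OC` is not yet measured. It differs from compound 3 in one place: 3,4-dimethoxyphenyl in place of 2-phenylethenyl on a saturated ring carbon. The two steps that bear on this change, from compound 1 and from compound 2 to compound 3, both show that exchanging an aryl group on that saturated ring carbon for 2-phenylethenyl raised the number by a modest amount. Putting an aryl group back is therefore expected to lower it again by a step of about that size, giving a 4.2-fold lower number from compound 3 to compound 4 (0.62 log units; beyond the scatter). For compound 4 the expected value is 3500 nM, with a likely range from 1500 nM to 9000 nM.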

Compound 4, concentration for total growth inhibition: 4360 nM
Compound 4: middle estimate off by 1.2-fold (0.10 log units), on the low side; measured number inside the range.
By their numbers in this assay, from the lowest: compounds 1, 2 and 4 (each within the scatter of the next); then compound 3.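

In this assay the return from 2-phenylethenyl to an aryl group on this saturated ring carbon now holds for a third aryl group, with a 3.3-fold lower number from compound 3 to compound 4 (0.52 log units; beyond the scatter) as the step, so the weaker result of compound 3 is not tied to the 2-hydroxyphenyl or 2-chlorophenyl comparison alone. The new group also leaves the result unchanged among the aryl compounds, since a 1.4-fold higher number from compound 2 to compound 4 (0.14 log units; within the scatter) and a 1.4-fold higher number from compound 1 to compound 4 (0.16 log units; within the scatter) are both within the scatter, and so 3,4-dimethoxyphenyl, with its 2 hydrogen-bond acceptors and 10 heavy atoms, cannot be told apart from the two earlier aryl groups in this assay, and among the four compounds only the 2-phenylethenyl of compound 3 stands apart. Nothing available explains either this sameness among the aryl groups or the separate standing of 2-phenylethenyl.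

Going by these compounds, whether the double bond of 2-phenylethenyl matters remains open, and a 2-phenylethyl group on the same ring carbon would address that. Also open, on these data alone, is whether the same result extends beyond phenyl rings, for instance to a pyridyl ring, a cyclohexyl ring or a short alkyl chain such as propyl.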